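A few compounds are considered here, and "the series" means these few. Any claim that something is new, unique, unknown or untested is made for them only; others in the source may bear on it.

Measured compounds in a functional assay on PC-3 cells (Homo sapiens) for antiproliferative activity, read by MTT assay, with a stated time of 48 h; a lower number here means a stronger inhibitor, a higher number a weaker inhibitor: compound 1 `COc1ccc(CN(C(=O)CSc2nnnn2C)c2cc(OC)c(OC)c(OC)c2)cc1` gives 10500 nM and compound 2 `COc1ccc(CN(C(=O)CSc2ccccn2)c2cc(OC)c(OC)c(OC)c2)cc1` gives 7510 nM.

Compound 2 stands lowest of the two numbers, its nearest neighbour being compound 1, which lies within the scatter of it. Going by the values given here, the only measured step, a 1.4-fold lower number from compound 1 to compound 2 (0.15 log units; within the scatter), touched the same region and moved nothing beyond the scatter. Compound 3 `COc1ccc(CN(C(=O)COc2cccc(Cl)c2)c2cc(OC)c(OC)c(OC)c2)cc1` continues at that place with 3-chlorophenoxy in place of (pyridin-2-yl)sulfanyl on a saturated chain carbon bound to a carbonyl carbon. Among the compounds with values here, only that one step bears on it, so no change beyond the scatter is expected in this assay, in either direction, and the step of a 1.0-fold lower number from compound 2 to compound 3 (0.00 log units; within the scatter) is the estimate. Compound 3 is expected to give 7500 nM, with a range from 2500 nM to 22000 nM.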

Compound 3, half-maximal inhibitory concentration: 30500 nM
Compound 3: the middle estimate sits 4.1-fold (0.61 log units) below what was measured; measured number above the stated range.
By their numbers in this assay, from the lowest: compounds 2 and 1 (each within the scatter of the next); then compound 3.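

In this assay, the saturated chain carbon bound to a carbonyl carbon now proves sensitive to the group it carries: a 4.1-fold higher number from compound 2 to compound 3 (0.61 log units; beyond the scatter) and a 2.9-fold higher number from compound 1 to compound 3 (0.46 log units; beyond the scatter), both beyond the scatter, whereas the exchange of the two sulfanyl groups stayed within it. Of the three groups shown, 3-chlorophenoxy alone separates from the others, towards a weaker inhibitor. Nothing at hand accounts for this shift.

Going by these compounds, the linking atom, the ring and the chlorine all change together, so which of them carries the step stays open. Plain phenoxy or (3-chlorophenyl)sulfanyl at this place would separate them.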